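This account rests on a few compounds, and the source may have more. Where it says the series, first, only, none or still open, it means among the compounds named here.

Measured compounds in a functional assay on SMMC-7721 cells (Homo sapiens) for antiproliferative activity, read by MTT assay, with a stated time of 48 h; on this read-out lower numbers stand for stronger inhibition and higher numbers for weaker inhibition:
- compound 1 `Cn1cc(C2=C(c3nn(CCCn4cncn4)c4ncccc34)C(=O)N(c3ccccc3)C2=O)c2ccccc21`: > 100000 nM, a limit of this assay.
- compound 2 `Cn1cc(C2=C(c3nn(CCCN4CCCCC4)c4ncccc34)C(=O)N(c3ccccc3)C2=O)c2ccccc21`: 3050 nM.
- compound 3 `Cn1cc(C2=C(c3nn(CCn4ccnc4)c4ncccc34)C(=O)N(c3ccccc3)C2=O)c2ccccc21`: > 100000 nM, a limit of this assay.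

Compound 3 stands at a limit, not a number; the same limit holds for compound 1, so two of the three values sit at the limit of > 100000 nM in this assay, at which 2 of the 3 values shown sit. Only compound 2 gives a readable number. Among the measured compounds shown here, the one step read in full is an at least 32-fold lower number from compound 1 to compound 2 (1.51 log units; beyond the scatter), and the step of an at least 32-fold higher number from compound 2 to compound 3 (1.51 log units; beyond the scatter) is its mirror. The step that the two limits leave unreadable from compound 1 to compound 3 is unreadable between two limits.

Compound 4 `Cn1cc(C2=C(c3nn(CCCn4ccnc4)c4ncccc34)C(=O)N(c3ccccc3)C2=O)c2ccccc21` differs from compound 3 by (1H-imidazol-1-yl)methyl in place of 1H-imidazol-1-yl on a saturated chain carbon, two bonds along the chain from an aromatic nitrogen; read one bond further out, it is 2-(1H-imidazol-1-yl)ethyl to 3-(1H-imidazol-1-yl)propyl. For the measured compounds named here, compound 4 thus carries a five-membered aromatic ring at the same place as compound 1, where the value is a limit, while the only readable number, compound 2, came with piperidin-1-yl at that place. Going by the values given here, no measured step maps this change directly. Compound 4 is therefore expected to stay near the limit, the step of an at least 1.1-fold lower number from compound 3 to compound 4 (0.04 log units; that floor lies within the scatter) being expected small and not readable beyond the scatter. The estimate for compound 4 is 90000 nM, with a range from 20000 nM to 300000 nM.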

Compound 4, half-maximal inhibitory concentration: 34800 nM
Estimate against measurement, compound 4: 2.6-fold (0.41 log units) above; the measured number falls inside the stated range.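

In this assay, compound 4 gives a readable number with a five-membered aromatic ring on this chain, so such a ring does not by itself leave a compound at the limit. Going from 2-(1H-imidazol-1-yl)ethyl to 3-(1H-imidazol-1-yl)propyl gives an at least 2.8-fold lower number from compound 3 to compound 4 (0.45 log units; beyond the scatter), and at the same chain length the change of ring gives an at least 2.8-fold lower number from compound 1 to compound 4 (0.45 log units; beyond the scatter); both are floors, set by a limit on one side. Piperidin-1-yl keeps a clear lead over 1H-imidazol-1-yl at this place, with an 11-fold higher number from compound 2 to compound 4 (1.06 log units; beyond the scatter).

From the compounds shown here alone, the step between compound 1 and compound 3 cannot be read, and how far either lies past its limit stays open: the limit of > 100000 nM in this assay, at which 2 of the 4 values shown sit. Whether the lead of piperidin-1-yl extends to morpholin-4-yl, to an open-chain dimethylamino group or to a longer chain such as 4-(piperidin-1-yl)butyl also remains open.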